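Replacing trifluoromethyl on the shared core: cyclopropyl next

A few compounds are considered here, and "the series" means these few. Any claim that something is new, unique, unknown or untested is made for them only; others in the source may bear on it.

Measured so far:
compound 1 `CCOC(=O)c1cnc(NN2C(=O)C=C(C)C2=O)nc1C(F)(F)F` — 2000 nM
compound 2 `CCOC(=O)c1cnc(NN2C(=O)C=C(C)C2=O)nc1CC` — 400 nM
compound 3 `CCOC(=O)c1cnc(NN2C(=O)C=C(C)C2=O)nc1-c1ccc(Cl)s1` — 520 nM

All three share one core and differ only in the group on one aromatic carbon. In a functional assay on Jurkat cells (Homo sapiens) for inhibition (a higher number here means a weaker inhibitor, a lower number a stronger inhibitor), compound 1 gives 2000 nM, the highest number of the three. The two changes away from trifluoromethyl both gave lower numbers: a 5.0-fold lower number from compound 1 to compound 2 (0.70 log units; beyond the scatter) and a 3.8-fold lower number from compound 1 to compound 3 (0.59 log units; beyond the scatter). Between compound 2 and compound 3 the gap is small, a 1.3-fold higher number from compound 2 to compound 3 (0.11 log units; within the scatter), so ethyl and 5-chlorothiophen-2-yl read alike here.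

Compound 4 `CCOC(=O)c1cnc(NN2C(=O)C=C(C)C2=O)nc1C1CC1` is not yet measured in this assay. It differs from compound 1 as follows: cyclopropyl in place of trifluoromethyl on an aromatic carbon

Among the compounds with values here, the steps that bear on this are those from compound 1 to compound 2 and from compound 1 to compound 3, both modest, both towards a lower number. Cyclopropyl, like ethyl, is a small carbon-only group, and nothing among the measured compounds points the other way. A modest step towards a lower number is therefore expected, a 4.0-fold lower number from compound 1 to compound 4 (0.60 log units; beyond the scatter), with the two known steps as its guide. Compound 4 is estimated at 500 nM, with a range from 200 nM to 1300 nM.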

Compound 4, half-maximal inhibitory concentration: 1500 nM
The estimate for compound 4 lay 3.0-fold (0.48 log units) below the measured number; the measured number lies above the stated range.
By their numbers in this assay, from the lowest: compounds 2 and 3 (each within the scatter of the next); then compounds 4 and 1 (each within the scatter of the next).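

A step of a 1.3-fold lower number from compound 1 to compound 4 (0.12 log units; within the scatter) leaves cyclopropyl and trifluoromethyl reading alike at this position in this assay, so removing trifluoromethyl does not by itself give a lower number. The steps of a 3.8-fold higher number from compound 2 to compound 4 (0.57 log units; beyond the scatter) and a 2.9-fold higher number from compound 3 to compound 4 (0.46 log units; beyond the scatter) show that ethyl and cyclopropyl, both carbon only, are not interchangeable here, and a ring alone does not set the number, as compound 3 also carries one. Nothing available here accounts for the difference between cyclopropyl and ethyl on this carbon.

As far as these compounds go, whether a longer chain such as propyl or butyl reads like ethyl remains open. From the compounds shown here alone, it is also open whether a larger carbon ring such as cyclobutyl, or an amine on this carbon, reads like cyclopropyl or like ethyl.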